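Removing the tert-butyl group from a benzothiazole analogue

A few compounds are considered here, and "the series" means these few. Any claim that something is new, unique, unknown or untested is made for them only; others in the source may bear on it.

Compound 1 `CC(C)(C)Oc1ccc(-c2nnc(SCCCN3CCN(c4nc5ccccc5o4)CC3)o2)cc1` gives 94900 nM
Compound 2 `Oc1ccc(-c2nnc(SCCCN3CCN(c4nc5ccccc5o4)CC3)o2)cc1` gives 260000 nM
Compound 3 `CC(C)(C)Oc1ccc(-c2nnc(SCCCN3CCN(c4nc5ccccc5s4)CC3)o2)cc1` gives 89300 nM

Of the compounds shown here, three have been tested in a functional assay on MCF7 cells (Homo sapiens) for inhibition, read by MTT assay, with a stated time of 72 h; a higher number here means a weaker inhibitor, a lower number a stronger inhibitor. All three share one core and differ only at two sites. Compound 2 differs from compound 1 by hydrogen in place of tert-butyl on an oxygen on an aromatic ring, and that change produced a 2.7-fold higher number from compound 1 to compound 2 (0.44 log units; beyond the scatter). Compound 3 differs from compound 1 by 1,3-benzothiazol-2-yl in place of 1,3-benzoxazol-2-yl on an amine nitrogen in a ring, which gave a 1.1-fold lower number from compound 1 to compound 3 (0.03 log units; within the scatter), so compound 1 and compound 3 cannot be told apart on this evidence.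

Compound 4 `Oc1ccc(-c2nnc(SCCCN3CCN(c4nc5ccccc5s4)CC3)o2)cc1` has not yet been measured. It differs from compound 3 by hydrogen in place of tert-butyl on an oxygen on an aromatic ring. This is the same change that leads from compound 1 to compound 2, at the same place, and here it sits on the core of compound 3 rather than that of compound 1. Because a 2.7-fold higher number from compound 1 to compound 2 (0.44 log units; beyond the scatter) was modest and because a 1.1-fold lower number from compound 1 to compound 3 (0.03 log units; within the scatter) lay within the scatter, the step from compound 3 to compound 4 is expected to be about a 2.7-fold higher number from compound 3 to compound 4 (0.43 log units; beyond the scatter). Compound 4 is therefore estimated at 240000 nM, with a likely range from 120000 nM to 500000 nM.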

Compound 4, half-maximal inhibitory concentration: 81900 nM
Compound 4: middle estimate off by 2.9-fold (0.47 log units), on the high side, and the stated range ends above it.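

In this assay, putting hydrogen in place of tert-butyl on the core carrying 1,3-benzothiazol-2-yl gave a 1.1-fold lower number from compound 3 to compound 4 (0.04 log units; within the scatter), so the loss seen on the other core did not carry over: the same change on two cores in this assay, a 2.7-fold higher number (0.44 log units; beyond the scatter) from compound 1 to compound 2 and a 1.1-fold lower number (0.04 log units; within the scatter) from compound 3 to compound 4, 3.0-fold (0.48 log units) apart, beyond the scatter of two such steps

Seen from the other side, 1,3-benzothiazol-2-yl in place of 1,3-benzoxazol-2-yl made no measurable difference with tert-butoxy present, yet with hydroxy present it gave a 3.2-fold lower number from compound 2 to compound 4 (0.50 log units; beyond the scatter), so this change also depends on its partner: the same change on two cores in this assay, a 1.1-fold lower number (0.03 log units; within the scatter) from compound 1 to compound 3 and a 3.2-fold lower number (0.50 log units; beyond the scatter) from compound 2 to compound 4, 3.0-fold (0.48 log units) apart, beyond the scatter of two such steps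

Within these four compounds, then, the effect of each change cannot be added to the other, but a single set of four does not show why, nor whether the same holds for any other group on that oxygen.

On these data alone, it remains open whether a methyl group on that oxygen, or an amine in place of hydroxy, would behave as on the core of compound 1 or as on the core of compound 3. As far as these compounds go, it is equally open whether a longer chain on the sulfur would preserve this dependence.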